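Phenyl in place of pyridin-3-yl on the amide carbonyl

The source may report more compounds than this note shows. Statements on the series, on what has been measured and on what is new or still open speak of the compounds shown alone.

Measured compounds: compound 1 `O=C(Nc1ccc(Cl)c(-c2nnc3c(Cl)cccn23)c1)c1cccnc1`, > 100000 nM; compound 2 `O=C(Nc1ccc(Cl)c(-c2nnc3c(Cl)cccn23)c1)c1cccc(Cl)c1`, 54800 nM; compound 3 `O=C(Nc1ccc(Cl)c(-c2nnc3c(Cl)cccn23)c1)c1cccnc1Cl`, > 100000 nM.

In a functional assay on MDA-MB-468 cells (Homo sapiens) for antiproliferative activity, read by MTT assay, with a stated time of 72 h (on this read-out lower numbers stand for stronger inhibition and higher numbers for weaker inhibition), compound 1 gives only a limit, not a number. Compound 1 therefore stands at the weak edge of the series, at the limit of > 100000 nM in this assay, at which 2 of the 3 values shown sit. Among the compounds with values here, compound 2 gives a number, and the step of an at least 1.8-fold lower number from compound 1 to compound 2 (0.26 log units; that floor lies within the scatter) is the only measured change at the carbonyl carbon that reads at all. Compound 3 again gives only a limit. The steps of an at least 1.8-fold higher number from compound 2 to compound 3 (0.26 log units; that floor lies within the scatter) and a step that the two limits leave unreadable from compound 1 to compound 3 add nothing readable.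

Compound 4 `O=C(Nc1ccc(Cl)c(-c2nnc3c(Cl)cccn23)c1)c1ccccc1` differs from compound 1 by phenyl in place of pyridin-3-yl on a carbonyl carbon. Phenyl lacks the chloro that 3-chlorophenyl carries, so the expected step of an at least 1.1-fold lower number from compound 1 to compound 4 (0.04 log units; that floor lies within the scatter) is small and may stay within the scatter, with a fair chance of another limit. Compound 4 is estimated at 90000 nM, within 40000 nM to 200000 nM.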

Compound 4, half-maximal inhibitory concentration: > 100000 nM
Compound 4 was reported as a limit; the forecaster's own chance of this, stated with the estimate: 50%; at least 1.1-fold (0.04 log units) between middle value and limit.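

Phenyl in place of pyridin-3-yl on the carbonyl carbon still yields no number, only a limit: the limit of > 100000 nM in this assay, at which 3 of the 4 values shown sit. Hydrogen in place of chloro on the aromatic carbon gives an at least 1.8-fold higher number from compound 2 to compound 4 (0.26 log units; that floor lies within the scatter), so the chloro of 3-chlorophenyl cannot be shown to matter beyond the scatter. The steps from compound 1 and from compound 3 to compound 4 cannot be read, since each joins two limits.

From the compounds shown here alone, whether a methoxy group, an amine or a carboxylic acid on the phenyl would give a clearly lower number remains open.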